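Aryl variation on the exocyclic double bond: expectation for compound 3

The compounds below may be only part of what the source reports. "The series", "measured", "known", "first", "only" and "open" are said of these compounds alone.

Working notes on the series. The shared core is carried by compound 1 `CC(=O)OC[C@H]1O[C@@H](n2cc(CN3C(=O)/C(=C\c4ccc(N(C)C)cc4)c4ccccc43)nn2)[C@H](OC(C)=O)[C@@H](OC(C)=O)[C@@H]1OC(C)=O` and compound 2 `CC(=O)OC[C@H]1O[C@@H](n2cc(CN3C(=O)/C(=C\c4ccc5ccccc5c4)c4ccccc43)nn2)[C@H](OC(C)=O)[C@@H](OC(C)=O)[C@@H]1OC(C)=O`; compound 3 `CC(=O)OC[C@H]1O[C@@H](n2cc(CN3C(=O)/C(=C\c4ccco4)c4ccccc43)nn2)[C@H](OC(C)=O)[C@@H](OC(C)=O)[C@@H]1OC(C)=O` has not been measured. In a functional assay on A549 cells (Homo sapiens) for cytotoxicity, read by sulforhodamine B assay, with a stated time of 48 h (a lower number here means a stronger inhibitor, a higher number a weaker inhibitor), compound 1 gives 17700 nM. In this assay, going by the values given here, compound 2 gives 62200 nM, the higher of the two numbers measured so far, and the step of a 3.5-fold higher number from compound 1 to compound 2 (0.55 log units; beyond the scatter) separates it from compound 1. Compound 3 differs from compound 2 in one place: furan-2-yl in place of naphthalen-2-yl on a double-bonded chain carbon bound to a double-bonded ring carbon. Among the compounds with values here, the only measured step bearing on this position is a 3.5-fold higher number from compound 1 to compound 2 (0.55 log units; beyond the scatter), itself an exchange of one aryl group for another on the same chain carbon; it shows that such an exchange can move the number beyond the scatter, but a single step gives no direction for the entry of furan-2-yl. Both measured numbers sit in the weak range, so compound 3 is expected to stay there. The step of a 1.8-fold lower number from compound 2 to compound 3 (0.25 log units; within the scatter) is estimated as modest, with wide uncertainty in either direction. For compound 3 the estimate in this assay is 35000 nM, with a range from 9000 nM to 140000 nM.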

Compound 3, half-maximal inhibitory concentration: 41100 nM
For compound 3 the middle estimate is 1.2-fold (0.07 log units) below the measured one; the range from low to high includes it.
By their numbers in this assay, from the lowest: compound 1; then compounds 3 and 2 (each within the scatter of the next).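

In this assay, the exchange gives a 1.5-fold lower number from compound 2 to compound 3 (0.18 log units; within the scatter): on the double-bonded chain carbon, furan-2-yl, with one five-membered aromatic ring with 1 hetero atom, cannot be told apart from naphthalen-2-yl, with 2 six-membered aromatic rings of carbon only, even though furan-2-yl has fewer heavy atoms. The second step, a 2.3-fold higher number from compound 1 to compound 3 (0.37 log units; beyond the scatter), shows that 4-(dimethylamino)phenyl stands apart from furan-2-yl as well as from naphthalen-2-yl, so compound 1 is the only one of the three with steps beyond the scatter to both others, and it carries the lowest number. No measurement shown here accounts for this difference.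

The compounds shown leave open whether the separation of compound 1 depends on the dimethylamino group itself, a question that unsubstituted phenyl or 4-aminophenyl on the same chain carbon would address. They also leave open whether the steps at this position hold when the acetyl ester groups of the shared core are replaced, for example by free hydroxyl groups.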